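From tert-butyl to phenyl on the aromatic ring

The source may report more compounds than this note shows. Statements on the series, on what has been measured and on what is new or still open speak of the compounds shown alone.

For the measured compounds named here, in a functional assay on the whole organism for inhibition, with Rattus norvegicus as the target (a lower number here means that less compound is needed, a higher number that more compound is needed for the effect), compound 3 `CC(C)c1ccc(OC(C)(Cc2ccc(C(C)(C)C)cc2)C(=O)O)cc1` gives 5 mg/kg, the only exact number among the measured compounds. Compound 1 `CC(C)c1ccc(OC(C)(Cc2ccc(C(F)(F)F)cc2)C(=O)O)cc1` shows only a limit, < 5 mg/kg. Compound 2 `Cc1ccc(CC(C)(Oc2ccc(C(C)C)cc2)C(=O)O)cc1` also shows only a limit, < 1 mg/kg. Compound 4 `CC(C)c1ccc(OC(C)(Cc2ccc(-c3ccccc3)cc2)C(=O)O)cc1` has phenyl in place of tert-butyl on an aromatic carbon. Going by the values given here, two measured steps bear on this place: tert-butyl in place of methyl gave an at least 5.0-fold higher number from compound 2 to compound 3 (0.69 log units; beyond the scatter), and tert-butyl in place of trifluoromethyl gave a number no lower from compound 1 to compound 3 (the limit leaves the size open). Neither brings in phenyl, so they set no clear direction here. The expected result in this assay is a 1.2-fold higher number from compound 3 to compound 4 (0.08 log units; within the scatter), with no shift beyond the scatter expected. Compound 4 is estimated at 6 mg/kg, within an expected range of 2 mg/kg to 20 mg/kg.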

Compound 4, dose for half-maximal effect: 1 mg/kg
Estimate against measurement, compound 4: 6.0-fold (0.78 log units) above; measured number outside the range, below it.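

Phenyl in place of tert-butyl gave a 5.0-fold lower number from compound 3 to compound 4 (0.70 log units; beyond the scatter) in this assay, the first step at this position between two exact numbers. Phenyl has more heavy atoms than tert-butyl, so the rise seen on going from methyl to tert-butyl does not extend to every larger group here. Nothing measured here accounts for this drop.

Phenyl in place of methyl gave a number no lower from compound 2 to compound 4 (the limit leaves the size open) in this assay. On these data alone, the step to compound 4 from compound 1 rests on a limit, and its size cannot be read, so the order between trifluoromethyl and phenyl stays open. As far as these compounds go, how an amine on this carbon would fall also stays open.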